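The source may hold more compounds than are shown below. What is called first, only, known or untested is meant among the compounds shown, and "the series" means these compounds.

In a functional assay on HT-29 cells (Homo sapiens) for inhibition, read by sulforhodamine B assay, with a stated time of 72 h (on this read-out higher numbers stand for weaker inhibition and lower numbers for stronger inhibition), three compounds on a shared core have been measured. Compound 1 `COc1cc2c(Nc3ccc(F)c(Cl)c3)ncnc2cc1OCCCCCCn1ccnc1[N+](=O)[O-]` gives 5630 nM, compound 2 `COc1cc2c(Nc3ccc(F)c(Cl)c3)ncnc2cc1OCCOCCn1ccnc1[N+](=O)[O-]` gives 9860 nM, and compound 3 `COc1cc2c(Nc3ccc(OCc4cccc(F)c4)c(Cl)c3)ncnc2cc1OCCOCCn1ccnc1[N+](=O)[O-]` gives 7640 nM. Compound 2 lies within the scatter of both others, so the three values form a single group with no meaningful order.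

Compound 4 `COc1cc2c(Nc3cccc(Br)c3)ncnc2cc1OCCOCCn1ccnc1[N+](=O)[O-]` departs from compound 2 in one place: 3-bromophenyl in place of 3-chloro-4-fluorophenyl on a nitrogen on an aromatic ring. In words, 3-bromophenyl stands in place of 3-chloro-4-fluorophenyl on a nitrogen on an aromatic ring. For the measured compounds named here, no measured compound carries the 3-bromophenyl group, so the data hold no direct test of this change.

The closest evidence is the exchange of fluoro for (3-fluorobenzyl)oxy on an aromatic carbon, which gives a 1.3-fold lower number from compound 2 to compound 3 (0.11 log units; within the scatter). The chain change bears on it less directly and gives a 1.8-fold higher number from compound 1 to compound 2 (0.24 log units; within the scatter). Both steps stay within the scatter, so no step beyond the scatter is expected in this assay, and no direction can be favoured with confidence. The expected step is a 1.2-fold lower number from compound 2 to compound 4 (0.06 log units; within the scatter). For compound 4 the estimated value is 8500 nM, with an expected range from 4000 nM to 18000 nM.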

Compound 4, half-maximal inhibitory concentration: 10800 nM
The estimate for compound 4 lay 1.3-fold (0.10 log units) below the measured number, and the stated range covers the measured number.
By their numbers in this assay, from the lowest: compounds 1, 3, 2 and 4 (each within the scatter of the next).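

In this assay, replacing the whole aryl group on this nitrogen, rather than only the fluoro on it, gives a 1.1-fold higher number from compound 2 to compound 4 (0.04 log units; within the scatter): the 3-chloro-4-fluorophenyl group, with its chlorine and fluorine, gives way to the 3-bromophenyl group, with its single bromine, and the number stays within the scatter. The earlier step at the fluoro-bearing carbon, a 1.3-fold lower number from compound 2 to compound 3 (0.11 log units; within the scatter), also stayed within the scatter, so neither of the two aryl changes made on the shared core of compound 2 separates its compound from compound 2 in this assay, although this says nothing about aryl changes beyond these two. Nothing available explains why the values stay together, and no cause can be assigned to this result.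

The compounds shown leave open whether a group of another kind on this aryl ring, such as an amine, a carboxylic acid or an ethynyl group, would give a step beyond the scatter. They also leave open whether the 3-bromophenyl group would behave the same way on the all-carbon chain of compound 1, or with a longer chain leading to the nitroimidazole.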